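The compounds below may be only part of what the source reports. "The series", "measured", "known", "first", "only" and "open" are said of these compounds alone.

Working notes on the series, read in a functional assay for inhibition, with Homo sapiens as the target; a higher number here means weaker binding, a lower number tighter binding. Compound 1 `Cc1ccc(C#N)c(OC(C)(C)C2OCC(C/C=C\CCC(=O)O)C(c3cccnc3)O2)c1` gives 15.9 nM, compound 2 `COc1ccccc1OC(C)(C)C1OCC(C/C=C\CCC(=O)O)C(c2cccnc2)O1` gives 224 nM and compound 3 `COc1ccc(OC(C)(C)C2OCC(C/C=C\CCC(=O)O)C(c3cccnc3)O2)c([N+](=O)[O-])c1` gives 6.17 nM, the lowest of the three numbers. These three share a core and differ only in the substituted phenyl group on the oxygen. That group moves the number widely: a 14-fold higher number from compound 1 to compound 2 (1.15 log units; beyond the scatter) and a 36-fold lower number from compound 2 to compound 3 (1.56 log units; beyond the scatter), both large, against the modest 2.6-fold lower number from compound 1 to compound 3 (0.41 log units; beyond the scatter).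

Compound 4 `CC(C)(Oc1ccc(F)cc1[N+](=O)[O-])C1OCC(C/C=C\CCC(=O)O)C(c2cccnc2)O1` keeps the nitro group of compound 3 and carries one change: fluoro in place of methoxy on an aromatic carbon, meta to a nitro group and para to a large group. Within the data shown here, no measured step makes this exchange, so any expectation is indirect. With the nitro group retained, the modest 2.6-fold lower number from compound 1 to compound 3 (0.41 log units; beyond the scatter) is taken as a better guide to size than the large 36-fold lower number from compound 2 to compound 3 (1.56 log units; beyond the scatter). A small rise in the number is expected, no larger than that modest step. The expected change is a 1.6-fold higher number from compound 3 to compound 4 (0.21 log units; within the scatter). The estimate for compound 4 is 10 nM, with an expected range of 3.5 nM to 32 nM.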

Compound 4, dissociation constant: 2.51 nM
Estimate against measurement, compound 4: 4.0-fold (0.60 log units) above; measured number below the stated range.
By their numbers in this assay, from the lowest: compound 4; then compound 3; then compound 1; then compound 2.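

Fluoro in place of methoxy, meta to a nitro group and para to a large group, lowers the number in this assay (a 2.5-fold lower number from compound 3 to compound 4 (0.39 log units; beyond the scatter)), so the methoxy group of compound 3 is not required for a low number at this position. Compound 4 now has the lowest number in the series, with the further steps (a 6.3-fold lower number from compound 1 to compound 4 (0.80 log units; beyond the scatter)) and (an 89-fold lower number from compound 2 to compound 4 (1.95 log units; beyond the scatter)) both beyond the scatter. No measurement available here explains the gain on going from methoxy to fluoro.

Going by these compounds, at this position, only methoxy and fluoro can be compared with the nitro group in place, so how a chloro or an amine group would read there stays open. Also open, on these data alone, is whether the gain from fluoro would hold with a nitrile in place of the nitro group.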